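This account rests on a few compounds, and the source may have more. Where it says the series, first, only, none or still open, it means among the compounds named here.

Measured so far:
compound 1 `Nc1ccc(-c2cc(=O)c3c(N)c(F)cc(F)c3o2)cc1F`: 40 nM
compound 2 `CCCCc1c(F)c(N)c2c(=O)cc(-c3ccc(N)c(F)c3)oc2c1F`: 8800 nM
compound 3 `Nc1ccc(-c2cc(=O)c3c(N)c(F)c(N)c(F)c3o2)cc1F`: 7.7 nM

In a functional assay on MCF7 cells (Homo sapiens) for cytotoxicity, read by neutral red uptake, with a stated time of 3 days (on this read-out lower numbers stand for stronger inhibition and higher numbers for weaker inhibition), compound 1 gives 40 nM, the second highest of the three numbers. Its nearest neighbour is reached by a 5.2-fold lower number from compound 1 to compound 3 (0.72 log units; beyond the scatter); its furthest by a 220-fold higher number from compound 1 to compound 2 (2.34 log units; beyond the scatter). Compound 4 `CN(C)c1c(F)c(N)c2c(=O)cc(-c3ccc(N)c(F)c3)oc2c1F` is the next compound in the series, and it differs from compound 1 by dimethylamino in place of hydrogen on an aromatic carbon.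

Two measured steps change that aromatic carbon of the shared core and therefore bear on this one. Adding butyl there produced a 220-fold higher number from compound 1 to compound 2 (2.34 log units; beyond the scatter), a large rise; adding amino produced a 5.2-fold lower number from compound 1 to compound 3 (0.72 log units; beyond the scatter), a modest fall. Dimethylamino carries a nitrogen, as amino does, but it also brings two carbons and no hydrogen-bond donor, so it sits between the two measured groups in what enters. Among the measured compounds shown here, no measured pair shows a dimethylamino anywhere. For the measured compounds named here, on balance a rise beyond the scatter is expected in this assay, smaller than the one seen with butyl, since the only group carrying nitrogen at that carbon gave a fall.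

Compound 4 is therefore estimated at 400 nM in this assay, with a likely range from 80 nM to 3000 nM. The expected step is a 10-fold higher number from compound 1 to compound 4 (1.00 log units; beyond the scatter).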

Compound 4, half-maximal inhibitory concentration: 39 nM
The estimate for compound 4 lay 10-fold (1.01 log units) above the measured number; measured number below the stated range.
By their numbers in this assay, from the lowest: compound 3; then compounds 4 and 1 (each within the scatter of the next); then compound 2.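

In this assay, dimethylamino on this aromatic carbon, ortho to two fluoro groups, stands level with hydrogen: a 1.0-fold lower number from compound 1 to compound 4 (0.01 log units; within the scatter). The large penalty seen with butyl therefore does not extend to every group with carbon atoms at this position, as a 230-fold lower number from compound 2 to compound 4 (2.35 log units; beyond the scatter) shows, and a group larger than hydrogen can sit here without any shift beyond the scatter. A nitrogen attached at this carbon does not by itself give the gain seen with amino, since the two methyl groups of dimethylamino go with a 5.1-fold higher number from compound 3 to compound 4 (0.70 log units; beyond the scatter); of the two nitrogen groups, only amino lies beyond the scatter from hydrogen.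

Nothing available explains why butyl, amino and dimethylamino differ at this carbon, so these remain observations of the numbers alone. Methylamino would fill the gap between amino and dimethylamino, while ethyl or methoxy would test whether the butyl penalty depends on chain length or on the atom attached to the ring, and a ring amine such as morpholine would show how much more bulk on nitrogen this position accepts.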